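Swapping amino for 4-chlorophenyl on a double-bonded nitrogen

The source may hold more compounds than are shown below. What is called first, only, known or untested is meant among the compounds shown, and "the series" means these compounds.

Of the compounds shown here, three sharing one core have been measured so far. In a functional assay on HCT-116 cells (Homo sapiens) for cytotoxicity, read by sulforhodamine B assay, with a stated time of 24 h (a lower number here means a stronger inhibitor, a higher number a weaker inhibitor), compound 2 `N/N=C1\C(=O)Nc2ccc(S(=O)(=O)N3CCOCC3)cc21` gives 36300 nM, and compound 1 `Cc1ccc(S(=O)(=O)N/N=C2\C(=O)Nc3ccc(S(=O)(=O)N4CCOCC4)cc32)cc1` gives 23400 nM. These two values lie within the usual scatter of each other, so they cannot be ranked. Compound 3 `O=C1Nc2ccc(S(=O)(=O)N3CCOCC3)cc2/C1=N/c1ccc(/N=C2\C(=O)Nc3ccc(S(=O)(=O)N4CCOCC4)cc32)cc1` gives 7480 nM, clearly lower than the value of compound 2.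

The next compound is compound 4 `O=C1Nc2ccc(S(=O)(=O)N3CCOCC3)cc2/C1=N/c1ccc(Cl)cc1`, in which 4-chlorophenyl takes the place of amino on a double-bonded nitrogen: 4-chlorophenyl in place of amino on a double-bonded nitrogen.

Only one measured step links two of these compounds: a 1.6-fold higher number from compound 1 to compound 2 (0.19 log units; within the scatter). There, hydrogen replaces (4-methylphenyl)sulfonyl on an amine nitrogen, and the change stays within the scatter, so it offers little guidance on size. Compound 3 is the closer guide, since it also has a six-membered aromatic ring of carbon only on a double-bonded nitrogen and reaches 7480 nM. However, it carries the core twice, so compound 4 need not match it.

A moderate move towards a lower number, meaning a stronger inhibitor, is therefore expected in this assay: a 2.4-fold lower number from compound 2 to compound 4 (0.38 log units; beyond the scatter). Compound 4 is estimated at 15000 nM, with an expected range from 6000 nM to 36000 nM.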

Compound 4, half-maximal inhibitory concentration: 24300 nM
For compound 4 the middle estimate is 1.6-fold (0.21 log units) below the measured one; the range from low to high includes it.
By their numbers in this assay, from the lowest: compound 3; then compounds 1, 4 and 2 (each within the scatter of the next).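

In this assay the swap of amino for 4-chlorophenyl on a double-bonded nitrogen gives a 1.5-fold lower number from compound 2 to compound 4 (0.17 log units; within the scatter) and so leaves compound 2 and compound 4 unranked. A single nitrogen gives way to 7 heavy atoms, including a six-membered aromatic ring of carbon only, and the hydrogen-bond donor and acceptor of the amino group are lost, yet no readable change follows. The ring alone also does not go with the lowest number seen so far, since compound 4 gives 24300 nM while compound 3 gives 7480 nM in the same test. Nothing measured here bears on the reason for this result.

With only amino, 4-chlorophenyl and the group of compound 3 shown on this nitrogen, it stays open how a plain phenyl without the chlorine, a phenyl ring carrying a carboxylic acid, or a short alkyl chain would behave. Among the compounds shown here, it also stays open whether any change here can move a compound with a single core beyond the scatter, as the one clearly lower value belongs to compound 3, which carries the core twice.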